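A few compounds are considered here, and "the series" means these few. Any claim that something is new, unique, unknown or untested is made for them only; others in the source may bear on it.

Measured so far in an in vitro assay on 293-EBNA cells for binding affinity to corticotropin-releasing factor receptor 1 (Homo sapiens); on this read-out lower numbers stand for stronger inhibition and higher numbers for weaker inhibition:
compound 1 `CCC(COC)Nc1nc(C)nc2c1nnn2-c1c(C)cc(C)cc1C` gives 59.4 nM
compound 2 `CCCC(C)Nc1nc(C)nc2c1nnn2-c1c(C)cc(C)cc1C` gives 7.1 nM
compound 3 `CCN(CC)c1nc(C)nc2c1nnn2-c1ccc(C(C)C)cc1Br` gives 25.3 nM

Compound 3 holds the second highest number of the three, with compound 1 nearest at a higher number and compound 2 furthest at a lower one. Compound 4 `CCC(Nc1nc(C)nc2c1nnn2-c1ccc(C(C)C)cc1Br)C(=O)OC` is the next step from compound 3: a group of 8 heavy atoms (5 carbon, 1 nitrogen, 2 oxygen; no ring) in place of a group of 5 heavy atoms (4 carbon, 1 nitrogen; no ring), on an aromatic carbon. Among the measured compounds shown here, only one measured step bears on a change of this kind. That step gave an 8.4-fold lower number from compound 1 to compound 2 (0.92 log units; beyond the scatter); read in reverse, exchanging a plain alkyl chain for one carrying oxygen, as in the 1-(methoxymethyl)propyl group of compound 1, raised the number markedly. For the measured compounds named here, the entering group of compound 4 likewise brings oxygen into the chain, but the swap also removes the diethylamino group itself, for which no measured pair exists, so the comparison is loose. A modest rise in number is expected for compound 4, a 1.8-fold higher number from compound 3 to compound 4 (0.25 log units; within the scatter). For compound 4 in this assay the estimate is 45 nM, in a range from 12 nM to 170 nM.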

Compound 4, inhibition constant: 19.4 nM
Compound 4: middle estimate off by 2.3-fold (0.37 log units), on the high side; low and high end bracket the measured number.
By their numbers in this assay, from the lowest: compound 2; then compounds 4 and 3 (each within the scatter of the next); then compound 1.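

In this assay the exchange of diethylamino for the group of 8 heavy atoms, on the aromatic carbon next to the ring nitrogen, gives a 1.3-fold lower number from compound 3 to compound 4 (0.12 log units; within the scatter) and so cannot be told apart from no change. This position therefore takes a group with a hydrogen-bond donor and 2 oxygen with no shift beyond the scatter, and a step of the size of an 8.4-fold lower number from compound 1 to compound 2 (0.92 log units; beyond the scatter) does not recur here, although the two steps exchange different groups on different molecules. No measurement at hand accounts for this result.

Open, going by these compounds, is which part of the entering group carries the result. The corresponding carboxylic acid, a primary amide or a plain 1-methylpropyl amine on the core of compound 4 would separate the ester from the chain.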